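Chloro for formyl on the pendant phenyl of compound 2

The source may hold more compounds than are shown below. What is called first, only, known or untested is meant among the compounds shown, and "the series" means these compounds.

For the measured compounds named here, compound 2 `O=Cc1ccc(-c2cn3ccnc3c(-c3ccc4ncn(C5CCCCC5)c4c3)n2)cc1` stands highest of the two numbers so far in a functional assay on NCI/ADR-RES cells (Homo sapiens) for inhibition, read by sulforhodamine B assay, with a stated time of 48 h, tested at 10 uM (on this read-out lower numbers stand for less inhibition and higher numbers for more inhibition at the one concentration tested (going by the name of the read-out)), where compound 2 gives 37.4%. Going by the values given here, compound 1 `Brc1cn2ccnc2c(-c2ccc3ncn(C4CCCCC4)c3c2)n1` gives 8.82% in this assay, and the step of a number 28.6 percentage points higher from compound 1 to compound 2 (beyond the scatter) is the only measured step. Compound 3 `Clc1ccc(-c2cn3ccnc3c(-c3ccc4ncn(C5CCCCC5)c4c3)n2)cc1` differs from compound 2 by chloro in place of formyl on an aromatic carbon. Among the compounds with values here, no measured step bears directly on this change: the one recorded step exchanged bromo for a whole 4-formylphenyl, a larger alteration than exchanging formyl for chloro on a phenyl that stays in place. With the phenyl retained, a step of a number 7.4 percentage points lower from compound 2 to compound 3 (within the scatter) is expected in this assay, most likely within the scatter or at most a small decrease. Compound 3 is therefore estimated at 30% in this assay, with a range from 10% to 55%.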

Compound 3, a percentage reported as inhibition, at one concentration (the size of the read-out at that concentration, not a potency): 11.1%
Compound 3: the middle estimate sits 18.9 percentage points above what was measured; the range from low to high includes it.
By their numbers in this assay, from the lowest: compounds 1 and 3 (each within the scatter of the next); then compound 2.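

In this assay the exchange of formyl for chloro on the aromatic carbon para to a large group is not neutral: a number 26.3 percentage points lower from compound 2 to compound 3 (beyond the scatter) marks this place as sensitive to the group carried on the phenyl. The step of a number 2.3 percentage points higher from compound 1 to compound 3 (within the scatter) shows that 4-chlorophenyl in place of bromo does not reproduce the rise of a number 28.6 percentage points higher from compound 1 to compound 2 (beyond the scatter) and that a phenyl at this place does not by itself give the higher number. No measured evidence here accounts for the difference between formyl and chloro.

With formyl the only group that stands apart, the compounds shown leave open whether an amine, a carboxylic acid or an acetyl group at this place would give a number like that of compound 2. They also leave open whether the formyl-to-chloro step keeps its size with a cyclopentyl or a longer chain in place of cyclohexyl.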